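Benzoyl to formyl on a shared core: an expectation

The compounds below may be only part of what the source reports. "The series", "measured", "known", "first", "only" and "open" are said of these compounds alone.

Measured compounds:
Compound 1 `COc1cccc(-c2c(-c3ccccc3)c(-c3ccccc3)n3ccc(C#N)cc23)c1`: in an assay for inhibition of Polyunsaturated fatty acid lipoxygenase ALOX15 (Oryctolagus cuniculus) (a higher number here means a weaker inhibitor, a lower number a stronger inhibitor), compound 1 gives "not determined" (no result reported).
Compound 2 `N#Cc1ccn2c(-c3ccccc3)c(-c3ccccc3)c(OCOCc3ccccc3)c2c1`: in this assay compound 2 gives 39000 nM.
Compound 3 `N#Cc1ccn2c(-c3ccccc3)c(-c3ccccc3)c(C(=O)c3ccccc3)c2c1`: in this assay compound 3 gives 43000 nM.

Compound 3 holds the highest of the two numbers reported, but its nearest neighbour is compound 2, and the step of a 1.1-fold higher number from compound 2 to compound 3 (0.04 log units; within the scatter) lies within the scatter, so the two cannot be ordered. Compound 1 contributes no number.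

Compound 4 `N#Cc1ccn2c(-c3ccccc3)c(-c3ccccc3)c(C=O)c2c1` differs from compound 3 by hydrogen in place of phenyl on a carbonyl carbon. For the measured compounds named here, the only measured step, the one from compound 2 to compound 3, exchanged one large group on the same aromatic carbon for another and moved the number by a 1.1-fold higher number from compound 2 to compound 3 (0.04 log units; within the scatter); it does not involve the formyl group and so bears on the new change only in showing that this position tolerated an exchange without a shift beyond the scatter. Going by the values given here, no step reports a shrinking of the group at this carbon. Compound 4 is therefore expected to stay close to compound 3, with a step of a 1.0-fold higher number from compound 3 to compound 4 (0.02 log units; within the scatter), in no clear direction beyond the scatter. The estimate for compound 4 in this assay is 45000 nM, within a range from 15000 nM to 135000 nM.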

Compound 4, half-maximal inhibitory concentration: 61000 nM
For compound 4 the middle estimate is 1.4-fold (0.13 log units) below the measured one, within the range that was stated.
By their numbers in this assay, from the lowest: compounds 2, 3 and 4 (each within the scatter of the next).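

In this assay, for the compounds shown here, the change from benzoyl to formyl gives a 1.4-fold higher number from compound 3 to compound 4 (0.15 log units; within the scatter), so this aromatic carbon now also shows a removal of phenyl that stays within the scatter, where the earlier step showed only one large group exchanged for another. The step of a 1.6-fold higher number from compound 2 to compound 4 (0.19 log units; within the scatter) also lies within the scatter, so (benzyloxy)methoxy, benzoyl and formyl cannot be ordered at this carbon. Nothing available offers an explanation for this result.

As far as these compounds go, whether an amine or a carboxylic acid on this carbon would move the number beyond the scatter remains open. Also open, from the compounds shown here alone, is what the nitrile and the two phenyl groups of the shared core contribute, as these stay the same in every compound with a reported number.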